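Acetamido for cyano on a sulfonamide series, L02 cytotoxicity

A few compounds are considered here, and "the series" means these few. Any claim that something is new, unique, unknown or untested is made for them only; others in the source may bear on it.

Compound 1 `N#Cc1ccc(S(=O)(=O)N2C/C(=C\c3ccncc3)C(=O)/C(=C/c3ccccc3F)C2)cc1` was tested in an ADME assay on L02 cells (Homo sapiens) for cytotoxicity, read by MTT assay, with a stated time of 24 h (on this read-out higher numbers stand for weaker inhibition and lower numbers for stronger inhibition), and its value, > 20000 nM, is a limit of the assay rather than a number. Compound 2 `CC(=O)Nc1ccc(S(=O)(=O)N2C/C(=C\c3ccncc3)C(=O)/C(=C/c3ccccc3F)C2)cc1` differs by acetamido in place of cyano on an aromatic carbon and gives 12300 nM; the step of an at least 1.6-fold lower number from compound 1 to compound 2 (0.21 log units; that floor lies within the scatter) is known only as a floor because of the limit of > 20000 nM in this assay, at which 1 of the 3 values shown sits. Compound 3 `N#Cc1ccc(S(=O)(=O)N2C/C(=C\c3ccncc3)C(=O)/C(=C/c3ccccc3C(F)(F)F)C2)cc1` differs from compound 1 by trifluoromethyl in place of fluoro on an aromatic carbon; in this assay compound 3 gives 17600 nM, a change of an at least 1.1-fold lower number from compound 1 to compound 3 (0.05 log units; that floor lies within the scatter). Compound 4 `CC(=O)Nc1ccc(S(=O)(=O)N2C/C(=C\c3ccncc3)C(=O)/C(=C/c3ccccc3C(F)(F)F)C2)cc1` is not yet measured; it differs from compound 3 by acetamido in place of cyano on an aromatic carbon, the same change as that from compound 1 to compound 2. Because that earlier step an at least 1.6-fold lower number from compound 1 to compound 2 (0.21 log units; that floor lies within the scatter) was small, compound 4 is expected to lie close to compound 3. In this assay the expected step is a 1.6-fold lower number from compound 3 to compound 4 (0.20 log units; within the scatter). Compound 4 is estimated at 11000 nM, between 5500 nM and 22000 nM.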

Compound 4, half-maximal inhibitory concentration: 10100 nM
Beside the measured number, compound 4's estimate is 1.1-fold (0.04 log units) above it, and the stated range covers the measured number.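

In this assay, acetamido in place of cyano gives a 1.7-fold lower number from compound 3 to compound 4 (0.24 log units; within the scatter), and trifluoromethyl in place of fluoro gives a 1.2-fold lower number from compound 2 to compound 4 (0.09 log units; within the scatter). Carried to the core of compound 3, the acetamido change shows no departure from the earlier step, but this does not show that the two steps are equal: the same change on two cores in this assay, an at least 1.6-fold lower number (0.21 log units; that floor lies within the scatter) from compound 1 to compound 2 and a 1.7-fold lower number (0.24 log units; within the scatter) from compound 3 to compound 4; the limit leaves it open whether they differ. The value of compound 1 is a limit and not a number, so the earlier step is known only as a floor: the limit of > 20000 nM in this assay, at which 1 of the 4 values shown sits.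

The compounds shown leave open how an amine or a carboxylic acid in place of the acetamido would read on these cores. They also leave open whether the change carries over to a core bearing chloro or methoxy in place of fluoro or trifluoromethyl.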